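Notes on the shared core: expectation for compound 4

The source may hold more compounds than are shown below. What is called first, only, known or untested is meant among the compounds shown, and "the series" means these compounds.

Within the data shown here, compound 2 `CCCSc1nc(=O)ccn1[C@@H]1O[C@H](COP(=O)(O)OP(=O)(O)O)[C@@H](O)[C@H]1O` is the only member of the series with a number in an in vitro functional assay on 1321-N1 cells for agonist activity at P2Y purinoceptor 4 (Homo sapiens), read by scintillation proximity assay and inositol phosphate accumulation (on this read-out lower numbers stand for an effect already at smaller amounts and higher numbers for an effect only at larger amounts of compound), where compound 2 gives 4900 nM. Compound 1 `CSc1nc(=O)ccn1[C@@H]1O[C@H](COP(=O)(O)O)[C@@H](O)[C@H]1O` reaches only a limit, > 100000 nM. Compound 3 `CCCSc1nc(=O)ccn1[C@@H]1O[C@H](COP(=O)(O)O)[C@@H](O)[C@H]1O` likewise reaches only a limit, > 100000 nM, so that the limit of > 100000 nM in this assay, at which 2 of the 3 values shown sit, gathers two of the three values. Among the measured compounds shown here, the step of an at least 20-fold higher number from compound 2 to compound 3 (1.30 log units; beyond the scatter) is the one measured step of readable size; the step that the two limits leave unreadable from compound 1 to compound 3 cannot be read. Compound 4 `CNc1nc(=O)ccn1[C@@H]1O[C@H](COP(=O)(O)OP(=O)(O)O)[C@@H](O)[C@H]1O` differs from compound 2 by methylamino in place of propylsulfanyl on an aromatic carbon. For the measured compounds named here, no measured step touches this position, the one readable step concerning the group on the oxygen. With compound 2 at 4900 nM as the sole anchor, compound 4 is estimated at 6000 nM, range 1000 nM to 40000 nM, the step of a 1.2-fold higher number from compound 2 to compound 4 (0.09 log units; within the scatter) being expected to stay near the scatter.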

Compound 4, half-maximal effective concentration: >= 100000 nM
Compound 4 ended at the assay's limit (the forecaster's own chance of this, stated with the estimate: 20%); middle value at least 16-fold (1.22 log units) from the limit.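

Among these compounds, the position on the aromatic carbon between two ring nitrogen atoms, which no earlier step touched, is not indifferent in this assay: methylamino in place of propylsulfanyl gives an at least 20-fold higher number from compound 2 to compound 4 (1.30 log units; beyond the scatter). Compound 2 therefore loses its measurable value through this change as well as through the change on the oxygen. Compound 4 gives a limit of the assay, not a number: the limit of >= 100000 nM in this assay, at which 1 of the 4 values shown sits.

Going by these compounds, it stays open whether the linking atom or the chain carries this loss. A propylamino or methylsulfanyl group on the core of compound 2 would separate the two, and a butylsulfanyl chain would extend the comparison.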